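A few compounds are considered here, and "the series" means these few. Any claim that something is new, unique, unknown or untested is made for them only; others in the source may bear on it.

Going by the values given here, compound 1, drawn as `COC(=O)/C=C(C)/C=C/C=C(C)/C=C/C1=C(C)C(n2ccnc2)CCC1(C)C`, is the only member of this small set with a number attached. In a functional assay on MCF7 cells for inhibition of cytochrome P450 26A1 (Homo sapiens) (on this read-out lower numbers stand for stronger inhibition and higher numbers for weaker inhibition), compound 1 gives 200 nM, and it therefore stands alone as the single reference point. Compound 2, drawn as `COC(=O)/C=C(C)/C=C/C=C(C)/C=C/C1=C(C)[C@H](n2ccnc2)CCC1(C)C`, shares the same skeleton but is drawn with a fixed handedness at one carbon, and in this assay compound 2 is recorded as "not determined" (no result reported); "not determined" (no result reported) (2 entries); the only thing that separates these two drawings is the fact that one of compounds 1 and 2 is drawn with a defined configuration and the other without, at the place where they differ. Compound 3, drawn as `CC1=C(/C=C/C(C)=C/C=C/C(C)=C/C(=O)O)C(C)(C)CCC1n1cncn1`, carries a free carboxylic acid and a different five-membered nitrogen ring, and in this assay compound 3 is likewise recorded as "not determined" (no result reported). Among the compounds with values here, no pair of measured compounds differs in one place, so no measured step is available to lean on.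

The unmeasured compound 4, drawn as `CC1=C(/C=C/C(C)=C/C=C/C(C)=C/C(=O)Nc2ccc(O)cc2)C(C)(C)CCC1n1ccnc1`, changes the far end of the chain: (4-hydroxyphenyl)amino in place of methoxy on a carbonyl carbon. Since nothing comparable has been measured here, the expectation for compound 4 can rest only on the size of the change. A step of a 1.5-fold higher number from compound 1 to compound 4 (0.18 log units; within the scatter) is expected, probably no larger than the usual scatter or a modest loss. Compound 4 is therefore estimated at 300 nM, with a plausible range from 60 nM to 1500 nM.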

Compound 4, half-maximal inhibitory concentration: 56 nM
Beside the measured number, compound 4's estimate is 5.4-fold (0.73 log units) above it; the measured number lies below the stated range.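

In this assay, going by these compounds alone, placing (4-hydroxyphenyl)amino instead of methoxy on the carbonyl carbon gives a 3.6-fold lower number from compound 1 to compound 4 (0.55 log units; beyond the scatter), the only measured step in this set and one that lies beyond the usual scatter. It shows that this end of the chain is not limited to a small group: a much larger group, bringing a six-membered aromatic ring and hydrogen-bond donors that methoxy lacks, is accepted here, and the number falls rather than rises. Nothing given here explains why the number falls.

The change swaps several features at once, so the aromatic ring, its hydroxy group and the amide hydrogen cannot be credited separately; simpler groups on the same carbonyl carbon, such as phenylamino or methylamino, would begin to pull these apart. From the compounds shown here alone, compounds 2 and 3 have no number to compare, so the steps to them cannot be read, and the effects of fixed handedness and of the different five-membered nitrogen ring remain open.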